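Compound 3 and a change in its chain

The compounds below may be only part of what the source reports. "The series", "measured", "known", "first", "only" and "open" are said of these compounds alone.

In a functional assay on HeLa cells (Homo sapiens) for inhibition, read by trypan blue exclusion, with a stated time of 72 h (a higher number here means a weaker inhibitor of growth, a lower number a stronger inhibitor of growth), compound 1 (`Cc1c(-c2ccc(O)c(O)c2)n(CCCCOc2ccccc2)c2ccc(O)cc12`) gives 10000 nM, compound 2 (`Cc1c(-c2ccc(O)cc2)n(CCCCOc2ccccc2)c2ccccc12`) gives 11000 nM and compound 3 (`Cc1c(-c2ccc(O)cc2)n(CCCCOc2ccccc2)c2ccc(O)cc12`) gives 4000 nM. Compound 3 has the lowest number of the three, and its gaps to both others lie beyond the scatter.

Compound 4 (`Cc1c(-c2ccc(O)cc2)n(CCCOc2ccccc2)c2ccc(O)cc12`) differs from compound 3 in the chain alone: phenoxy in place of phenoxymethyl on a saturated chain carbon, three bonds along the chain from an aromatic nitrogen. This is phenoxy in place of phenoxymethyl on a saturated chain carbon, three bonds along the chain from an aromatic nitrogen.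

Two measured steps lead to compound 3, and both are modest. With hydrogen in place of hydroxy on an aromatic carbon, the step is a 2.5-fold lower number from compound 1 to compound 3 (0.40 log units; beyond the scatter). With hydroxy in place of hydrogen on an aromatic carbon, the step is a 2.8-fold lower number from compound 2 to compound 3 (0.44 log units; beyond the scatter). Neither step touches the chain, so the series holds no direct measure of this change and gives no direction for it. They serve only as a guide to size, so no step beyond the scatter is expected in this assay, with a slightly higher number as a tentative guess. The expected step is a 1.3-fold higher number from compound 3 to compound 4 (0.10 log units; within the scatter). The estimate for compound 4 is 5000 nM, with an expected range of 1800 nM to 12000 nM.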

Compound 4, concentration for 50% growth inhibition: 4400 nM
Compound 4: the middle estimate sits 1.1-fold (0.06 log units) above what was measured; low and high end bracket the measured number.
By their numbers in this assay, from the lowest: compounds 3 and 4 (each within the scatter of the next); then compounds 1 and 2 (each within the scatter of the next).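

In this assay, phenoxy in place of phenoxymethyl on a saturated chain carbon, three bonds along the chain from an aromatic nitrogen, gives a 1.1-fold higher number from compound 3 to compound 4 (0.04 log units; within the scatter). Among these compounds, this is the first direct reading of the chain, since the two earlier steps, both beyond the scatter, concerned hydroxy on aromatic carbons and said nothing about this position. With the rest of compound 3 held fixed, this particular change leaves the two compounds indistinguishable in this assay, so the read-out does not separate phenoxymethyl from phenoxy here, and no measurement at hand explains that result.

One pair is a narrow basis: it leaves open whether a longer chain, or an amine or a carboxylic acid in place of phenoxy, would produce a step beyond the scatter at this position. It also leaves open whether the same chain change would read the same way on the hydroxy patterns of compound 1 and compound 2, as the compounds shown carry the phenoxy group only on the hydroxy pattern of compound 3.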